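Amidrazone thiosemicarbazides: removing the ring methyl

The compounds below may be only part of what the source reports. "The series", "measured", "known", "first", "only" and "open" are said of these compounds alone.

Three analogues share a pyridine-bearing amidrazone thiosemicarbazide core: compound 1 `Cc1ccnc(/C(N)=N/NC(=S)N2CCSCC2)c1`, compound 2 `Cc1cccc(/C(N)=N/NC(=S)N2CCCCC2)n1` and compound 3 `Cc1cccc(/C(N)=N/NC(=S)N2CCCC2)n1`. In a functional assay on MCF7 cells (Homo sapiens) for cytotoxicity, read by MTT assay, with a stated time of 72 h, tested at 100 uM (on this read-out higher numbers stand for more inhibition of growth at the one concentration tested and lower numbers for less inhibition of growth), compound 1 gives 76.8%, compound 2 gives 54% and compound 3 gives 61.8%. Compound 2 stands lowest of the three; against compound 3 the gap is a number 7.8 percentage points higher from compound 2 to compound 3 (within the scatter), while compound 1 lies beyond the scatter above it, though that pair differs in more than one place and is not a clean step.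

Compound 4 `N/C(=N\NC(=S)N1CCCCC1)c1ccccn1` is not yet measured. It differs from compound 2 by hydrogen in place of methyl on an aromatic carbon. Among the compounds with values here, no measured step touches this change: the only single-place step, a number 7.8 percentage points higher from compound 2 to compound 3 (within the scatter), concerns the amine ring on the thiocarbonyl carbon, not the aromatic ring, and it stayed within the scatter. There is therefore no basis to expect a shift beyond the scatter in this assay in either direction, and the expected step is no change at the digits printed from compound 2 to compound 4 (within the scatter). Compound 4 is estimated at 54%, with a range from 36% to 72%.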

Compound 4, percent growth inhibition at one concentration: 77.7%
For compound 4 the middle estimate is 23.7 percentage points below the measured one; measured number outside the range, above it.
By their numbers in this assay, from the lowest: compounds 2 and 3 (each within the scatter of the next); then compounds 1 and 4 (each within the scatter of the next).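

Hydrogen in place of methyl on an aromatic carbon next to the ring nitrogen gives a number 23.7 percentage points higher from compound 2 to compound 4 (beyond the scatter) in this assay and is the only single-place step here that lies beyond the scatter. Within the data shown here, the other such step, a number 7.8 percentage points higher from compound 2 to compound 3 (within the scatter), changes the amine ring on the thiocarbonyl carbon, so this is the first sign that the series responds to a change on the aromatic ring, with the methyl-bearing compound 2 giving the lower number. Nothing available explains why removing this methyl has that effect.

Only methyl and hydrogen are compared at this place, so an ethyl group, a methoxy group or a chlorine atom there could show whether the step is specific to methyl. Going by these compounds, it also remains open whether the same change holds with pyrrolidin-1-yl in place of piperidin-1-yl on the thiocarbonyl carbon.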